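Fluoro in Place of Hydrogen on Compound 1

The source may hold more compounds than are shown below. What is called first, only, known or untested is meant among the compounds shown, and "the series" means these compounds.

Among the measured compounds shown here, in a functional assay on EKVX cells (Homo sapiens) for inhibition (a lower number here means a stronger inhibitor of growth, a higher number a weaker inhibitor of growth), compound 1 `COc1ccc(-n2cnnc2-c2cc(OC)c(OC)c(OC)c2)cc1` gives 37200 nM, the only actual number so far. Compound 2 `COc1cc(-c2nncn2-c2ccc(N(C)C)cc2)cc(OC)c1OC` is reported only as a limit, < 100000 nM. For the measured compounds named here, the sole measured step, a step that the limit leaves unreadable from compound 1 to compound 2, puts dimethylamino in place of methoxy and has no readable size to carry over. Compound 3 `COc1ccc(-n2cnnc2-c2cc(OC)c(OC)c(OC)c2)cc1F` differs from compound 1 by fluoro in place of hydrogen on an aromatic carbon. With no measured size to go on, the expected step, a 1.1-fold lower number from compound 1 to compound 3 (0.03 log units; within the scatter), stays within the scatter. Compound 3 is expected at 35000 nM, with an estimated range of 14000 nM to 90000 nM.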

Compound 3, concentration for 50% growth inhibition: 89100 nM
Compound 3: middle estimate off by 2.5-fold (0.41 log units), on the low side; measured number inside the range.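

Fluoro in place of hydrogen, ortho to a methoxy group and meta to a large group, gives the first readable step in this assay, and that step is a 2.4-fold higher number from compound 1 to compound 3 (0.38 log units; beyond the scatter). A single fluoro atom at this position is therefore enough to weaken growth inhibition beyond the scatter. Compound 2 is reported only as a limit, and the number for compound 3 lies close to it: the limit of < 100000 nM in this assay, at which 1 of the 3 values shown sits.

As far as these compounds go, whether chloro, hydroxyl or an amine at this position would move the number the same way stays open. So does the effect of fluoro elsewhere on this ring.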